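Amide to Ester on a Long Chain: Compound 4 Expected

A few compounds are considered here, and "the series" means these few. Any claim that something is new, unique, unknown or untested is made for them only; others in the source may bear on it.

Of the compounds shown here, three built on one shared core have been measured in an assay on isolated protein (Mus musculus) for inhibition of IL15-IL15 receptor (Homo sapiens), read by resazurin assay, with stated times of 30 min and 2.5 days; on this read-out higher numbers stand for weaker inhibition and lower numbers for stronger inhibition. Compound 1 `Cn1c(Cc2nn(C)c(=O)c3ccccc23)nnc1SCCCCCCCCCCC(=O)Nc1ccccc1Cl` gives 15000 nM and stands second highest among the three numbers. Compound 3 `Cn1c(Cc2nn(C)c(=O)c3ccccc23)nnc1SCCCCCCCC(=O)Nc1ccc(O)cc1O` gives 17000 nM, which lies within the usual scatter of the number for compound 1, so no order between the two can be read. Among the compounds with values here, compound 2 `Cn1c(Cc2nn(C)c(=O)c3ccccc23)nnc1SCCCCCC(=O)Nc1ccc(Cl)cc1Cl` gives 4100 nM, a lower number than that of compound 1 by a margin beyond the scatter, though the two structures differ in more than one place and no single step connects them.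

Compound 4 `Cn1c(Cc2nn(C)c(=O)c3ccccc23)nnc1SCCCCCCCCCCC(=O)Oc1ccc(Cl)cc1Cl` has not yet been measured in this assay. It arises from compound 1 by the change (2,4-dichlorophenoxy in place of (2-chlorophenyl)amino on a carbonyl carbon). Within the data shown here, no measured pair shows this change on its own, so the expectation rests only on the range of numbers seen so far. Compound 4 is expected to give a number near that of compound 1, with the step from compound 1 to compound 4 estimated at a 1.5-fold lower number from compound 1 to compound 4 (0.18 log units; within the scatter), a change that may well fall within the scatter. The estimate for compound 4 in this assay is 10000 nM, with a range from 3000 nM to 40000 nM.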

Compound 4, half-maximal inhibitory concentration: 8700 nM
Estimate against measurement, compound 4: 1.1-fold (0.06 log units) above; the range from low to high includes it.
By their numbers in this assay, from the lowest: compound 2; then compounds 4, 1 and 3 (each within the scatter of the next).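

In this assay, putting 2,4-dichlorophenoxy in place of (2-chlorophenyl)amino on a carbonyl carbon whose other neighbour is a saturated chain carbon gives a 1.7-fold lower number from compound 1 to compound 4 (0.24 log units; within the scatter), the first step read at this place. On this long chain, then, the amide hydrogen can be lost and the change from amide to ester made without a shift beyond the scatter, although this rests on a single pair. No measurement at hand bears on why the number holds.

The step joins two changes, so the shares of the oxygen and of the added chlorine stay unresolved; a 2-chlorophenoxy ester or a 2,4-dichlorophenyl amide on the same chain would separate them. Going by these compounds, what a carboxylic acid or an N-methyl amide at this carbonyl carbon would give also remains open.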